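The source may hold more compounds than are shown below. What is called first, only, known or untested is meant among the compounds shown, and "the series" means these compounds.

Measured compounds in a functional assay on KB cells (Homo sapiens) for cytotoxicity, read by MTT assay, with a stated time of 72 h; on this read-out higher numbers stand for weaker inhibition and lower numbers for stronger inhibition:
Compound 1 `COc1cc2ncnc(NNC(=S)NC(=O)c3ccccc3C)c2cc1OC` gives 11400 nM
Compound 2 `O=C(NC(=S)NNc1ncnc2ccccc12)c1cccc(Cl)c1` gives 4740 nM
Compound 3 `O=C(NC(=S)NNc1ncnc2ccccc12)c1ccc(F)cc1` gives 1870 nM

Among these three, compound 1 stands highest, so it is the weakest inhibitor shown; compound 2 sits below it, and compound 3 sits lower still, each gap beyond the usual scatter. Compound 4 `COc1cc2ncnc(NNC(=S)NC(=O)c3ccc(C)cc3)c2cc1OC` is not yet measured. It keeps every atom of compound 1 but joins them differently: 4-methylphenyl in place of 2-methylphenyl on a carbonyl carbon. Among the measured compounds shown here, only one measured step touches the same place, the aryl group on the carbonyl carbon: a 2.5-fold lower number from compound 2 to compound 3 (0.40 log units; beyond the scatter). That step, however, sits on a core without the two methoxy groups and swaps one halogen for another rather than moving a methyl, so it bears on compound 4 only loosely. It shows that changing the aryl group at this position can shift the number modestly, and nothing here points to a large move in either direction. A small lowering of the number is therefore expected for compound 4, of the size a 1.8-fold lower number from compound 1 to compound 4 (0.24 log units; within the scatter), which may well lie within the scatter. The estimate for compound 4 in this assay is 6500 nM, with a range from 2500 nM to 16000 nM.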

Compound 4, half-maximal inhibitory concentration: 24200 nM
Compound 4: the middle estimate sits 3.7-fold (0.57 log units) below what was measured; measured number outside the range, above it.
By their numbers in this assay, from the lowest: compound 3; then compound 2; then compound 1; then compound 4.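

In this assay moving the methyl group on the aryl ring at the carbonyl carbon, with no atom added or lost, produces a 2.1-fold higher number from compound 1 to compound 4 (0.33 log units; beyond the scatter) and this modest step lies beyond the usual scatter. The earlier comparison at this position exchanged one halogen-bearing aryl group for another on a core without the two methoxy groups, whereas this pair isolates the place of a single methyl group on the methoxy-bearing core and shows that 2-methylphenyl gives the lower number and so the stronger inhibition of the two. Nothing measured here accounts for this difference.

The compounds shown leave open whether the same move of the methyl group would change the number in the same direction and by a similar amount on the core without the two methoxy groups. They also leave open how an amine, a carboxylic acid or a longer chain such as butyl on this aryl ring would change the number in this cell assay.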